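The compounds below may be only part of what the source reports. "The series", "measured", "known", "first", "only" and "open" are said of these compounds alone.

Compound 1 `CC1=C(C(=O)Nc2ccc(Cl)cc2)C(c2ccco2)C(C(=O)Nc2ccc(Cl)cc2)=C(C)N1` and compound 2 `CC1=C(C(=O)Nc2ccc(Cl)cc2)C(c2ccccc2O)C(C(=O)Nc2ccc(Cl)cc2)=C(C)N1` share one core, while compound 3 `COc1ccc(NC(=O)C2=C(C)NC(=O)NC2c2ccco2)cc1` and compound 4 `COc1ccc(NC(=O)C2=C(C)NC(=O)NC2c2ccccc2O)cc1` share another; the difference between the two cores is not broken down here. In an ADME assay on Vero cells (Chlorocebus sabaeus) for cytotoxicity, read by sulforhodamine B assay, with a stated time of 3 days (on this read-out higher numbers stand for lower toxicity in this test and lower numbers for higher toxicity in this test), compound 1 gives 24 ug/mL, and compound 2 gives 62 ug/mL. The change between them is 2-hydroxyphenyl in place of furan-2-yl on a saturated ring carbon, and it produced a step of a 2.6-fold higher number from compound 1 to compound 2 (0.41 log units; beyond the scatter). Compound 3 gives 210 ug/mL in this assay, the highest of the three numbers measured. Compound 4 carries the same kind of change relative to compound 3, (2-hydroxyphenyl in place of furan-2-yl on a saturated ring carbon), though the surroundings differ: in compound 1 the saturated ring carbon sits in a six-membered non-aromatic ring with 1 nitrogen, next to two ring atoms that each bear a (4-chlorophenyl)carbamoyl group, whereas in compound 3 it sits in a six-membered non-aromatic ring with 2 nitrogen, next to the ring nitrogen and next to the ring atom that bears a large group. A step of a 2.1-fold higher number from compound 3 to compound 4 (0.33 log units; beyond the scatter) is expected for compound 4, resting on the earlier step of a 2.6-fold higher number from compound 1 to compound 2 (0.41 log units; beyond the scatter). Compound 4 is therefore estimated at 450 ug/mL, between 180 ug/mL and 1000 ug/mL.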

Compound 4, half-maximal cytotoxic concentration: 160 ug/mL
Beside the measured number, compound 4's estimate is 2.8-fold (0.45 log units) above it, and the stated range ends above it.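

On the core of compound 3, the change from furan-2-yl to 2-hydroxyphenyl gives a 1.3-fold lower number from compound 3 to compound 4 (0.12 log units; within the scatter) in this assay, so compound 3 and compound 4 cannot be told apart in this read-out. The step seen on the core of compound 1 therefore did not carry over to the core of compound 3: the same change on two cores in this assay, a 2.6-fold higher number (0.41 log units; beyond the scatter) from compound 1 to compound 2 and a 1.3-fold lower number (0.12 log units; within the scatter) from compound 3 to compound 4, 3.4-fold (0.53 log units) apart, beyond the scatter of two such steps This shows that, for these four compounds, a step measured on one core was not a safe guide to the other, but with a single pair on each core it does not show which feature of the two cores accounts for the gap, nor does it give a rule for any further core.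

The compounds shown leave open whether the two cores would also part ways with another group on the saturated ring carbon, such as a phenyl ring carrying an amine or a carboxylic acid. They also leave open whether a methoxy group or a longer alkyl chain in place of the hydroxyl of 2-hydroxyphenyl would give the same picture.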